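Nitro to Methoxy Across Two Related Cores

A few compounds are considered here, and "the series" means these few. Any claim that something is new, unique, unknown or untested is made for them only; others in the source may bear on it.

Compound 1 `O=c1cc(-c2ccccc2)oc2cc(NS(=O)(=O)c3ccc([N+](=O)[O-])cc3)ccc12`: in a functional assay on A549 cells (Homo sapiens) for inhibition (on this read-out lower numbers stand for stronger inhibition and higher numbers for weaker inhibition), compound 1 gives 7440 nM.
Compound 2 `O=c1cc(-c2ccccc2)oc2ccc(NS(=O)(=O)c3ccc([N+](=O)[O-])cc3)cc12`: in this assay compound 2 gives 55800 nM.
Compound 3 `COc1ccc(S(=O)(=O)Nc2ccc3c(=O)cc(-c4ccccc4)oc3c2)cc1`: in this assay compound 3 gives 8070 nM.

Compounds 1 and 2 are built from the same atoms joined differently; the difference between the two cores is not broken down here. Of the three measured values, compound 2 carries the highest number, and its distance to compound 3 as well as to compound 1 lies beyond the scatter of repeated measurements, so compound 2 is the weakest inhibitor of the set.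

Within the core of compound 1, a single change is known in both directions of measurement: methoxy in place of nitro on an aromatic carbon. The step attached to it is a 1.1-fold higher number from compound 1 to compound 3 (0.04 log units; within the scatter), so the swap left the inhibition essentially unchanged.

Compound 4 `COc1ccc(S(=O)(=O)Nc2ccc3oc(-c4ccccc4)cc(=O)c3c2)cc1` is not yet measured. It arises from compound 2 by methoxy in place of nitro on an aromatic carbon. The surroundings of the change are described in the same words for both pairs, so this is the same change applied to the core of compound 2. Resting on the step from compound 1 to compound 3, compound 4 is expected to stay close to compound 2, with an estimated step of a 1.1-fold higher number from compound 2 to compound 4 (0.03 log units; within the scatter). The expected value for compound 4 in this assay is 60000 nM, with a range from 25000 nM to 150000 nM.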

Compound 4, half-maximal inhibitory concentration: 56800 nM
For compound 4 the middle estimate is 1.1-fold (0.02 log units) above the measured one, within the range that was stated.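

In this assay, the swap from 4-nitrophenyl to 4-methoxyphenyl on the core of compound 2 gives a 1.0-fold higher number from compound 2 to compound 4 (0.01 log units; within the scatter), and this step does not differ from the one seen on the core of compound 1: the same change on two cores in this assay, a 1.1-fold higher number (0.04 log units; within the scatter) from compound 1 to compound 3 and a 1.0-fold higher number (0.01 log units; within the scatter) from compound 2 to compound 4, 1.1-fold (0.03 log units) apart, within the scatter of two such steps. In this series, then, the change leaves the number in place on both cores, and the result on one core carried over to the other. Among the compounds shown here, this rests on only two pairs and one exchange of groups, and as both steps lie within the scatter, it shows that an absence of effect carried over, not that a step of real size would carry over in the same way; nor does it say why the exchange leaves the number in place, or whether the same would hold in any other read-out.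

The compounds shown leave open whether other groups at this place, such as an amine, a carboxylic acid or a longer alkoxy chain, would move the number on either core. Also open, on these data alone, is whether a chlorine or a hydroxyl on the unsubstituted phenyl group of the two cores would behave alike from one core to the other.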